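The compounds below may be only part of what the source reports. "The series", "measured", "known", "first", "only" and "open" are said of these compounds alone.

In a functional assay on K562 cells (Homo sapiens) for cytotoxicity, read by trypan blue exclusion, with a stated time of 96 h (a higher number here means a weaker inhibitor, a lower number a stronger inhibitor), compound 1 (`COc1ccc(NS(=O)(=O)/C=C/c2c(OC)cc(OC)cc2OC)cc1`) gives 75 nM and compound 2 (`COc1cc(OC)c(/C=C/S(=O)(=O)Nc2ccc(OC)c(F)c2)c(OC)c1`) gives 75 nM. Going by the values given here, the step of no change at the digits printed from compound 1 to compound 2 (within the scatter) is the only measured single-site step, and it does not touch the site of the next change. Compound 3 (`COC(=O)C(Nc1cc(NS(=O)(=O)/C=C/c2c(OC)cc(OC)cc2OC)ccc1OC)c1ccc(Cl)cc1`) gives 2500 nM, the highest number of the three and beyond the scatter of both others. Compound 4 (`COc1cc(OC)c(/C=C/S(=O)(=O)Nc2ccc(OC)c(NCC(=O)O)c2)c(OC)c1`) differs from it by carboxymethyl in place of (4-chlorophenyl)(methoxycarbonyl)methyl on a nitrogen on an aromatic ring. Among the compounds with values here, no measured step covers this exchange, so the only guide is that compound 3 at 2500 nM stands well above compound 1 at 75 nM, which carries no substituent on that nitrogen. A moderate step to a lower number in this assay is therefore expected, estimated as a 6.3-fold lower number from compound 3 to compound 4 (0.80 log units; beyond the scatter). For compound 4 the expected value is 400 nM, with an estimated range of 80 nM to 3000 nM.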

Compound 4, half-maximal inhibitory concentration: 20 nM
Compound 4: middle estimate off by 20-fold (1.30 log units), on the high side; the measured number lies below the stated range.
By their numbers in this assay, from the lowest: compound 4; then compounds 1 and 2 (each within the scatter of the next); then compound 3.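

In this assay the nitrogen on an aromatic ring tolerates a substituent, and the choice of group matters: carboxymethyl in place of (4-chlorophenyl)(methoxycarbonyl)methyl gives a 130-fold lower number from compound 3 to compound 4 (2.10 log units; beyond the scatter). The (carboxymethyl)amino group also gives stronger inhibition than hydrogen or fluoro on that aromatic carbon, with a 3.8-fold lower number from compound 1 to compound 4 (0.57 log units; beyond the scatter) and a 3.8-fold lower number from compound 2 to compound 4 (0.57 log units; beyond the scatter). No measured evidence accounts for these steps. Going by these compounds, whether the gain requires the free carboxylic acid remains open. Its methyl ester, the unsubstituted amine and a longer carboxyethyl chain are not among the compounds shown.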